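The source may report more compounds than this note shows. Statements on the series, on what has been measured and on what is new or still open speak of the compounds shown alone.

Compound 1 `CN1Cc2ccc(OCc3ccccc3)cc2[C@@H](O)C1` carries the shared core with a benzyl ether on its outer side. In an ADME assay on Vero cells (Chlorocebus sabaeus) for cytotoxicity, read by sulforhodamine B assay, with a stated time of 72 h (on this read-out lower numbers stand for stronger inhibition and higher numbers for weaker inhibition), compound 1 gives > 100000 nM, which is a limit of the assay rather than a measured number. Compound 2 `CN1Cc2ccc(OCCOc3ccccc3)cc2[C@@H](O)C1` keeps the same core with a longer link out to its outer ring. In this assay compound 2 gives > 100000 nM, again a limit and not a number. Compound 1 therefore stands at the edge of what this test can report, and it does not stand there alone: the limit of > 100000 nM in this assay, at which 2 of the 2 values shown sit. Among the compounds with values here, neither value says where, beyond that edge, a true figure would fall, so no step between measured compounds can be drawn.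

Compound 3 `CN1Cc2ccc(OCc3ccc(Br)cc3)cc2[C@@H](O)C1` is not yet measured. Against compound 1 the change is bromo in place of hydrogen on an aromatic carbon, a hydrogen leaving and a bromo entering, so the outer ring turns from phenyl to 4-bromophenyl. With both measured values resting at the limit, the expected step of a number no higher from compound 1 to compound 3 (the limit leaves the size open) is none beyond the usual scatter. Compound 3 is expected to give 100000 nM, within a range from 50000 nM to 300000 nM, and most likely the assay again reports only its limit.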

Compound 3, half-maximal inhibitory concentration: 37000 nM
For compound 3 the middle estimate is 2.7-fold (0.43 log units) above the measured one, outside the stated range (below it).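

Placing bromo on an aromatic carbon, para to a large group, produces the first change in this series that can be read as a step in this assay: an at least 2.7-fold lower number from compound 1 to compound 3 (0.43 log units; beyond the scatter). Going by these compounds, the true size of that step remains unknown, since the value of > 100000 nM for compound 1 is a limit and not a number, so the step gives only the smallest change consistent with the data. Even so, a single added heavy atom on the outer ring is enough to bring a compound within the range of the test, showing that this position is not indifferent to the change, and the result stands out against the other values: the limit of > 100000 nM in this assay, at which 2 of the 3 values shown sit.

The compounds shown hold no other group at this place, such as chloro, methoxy or an amine, so it stays open whether this shift belongs to bromo alone or would follow from other groups there. On these data alone, it is also open whether bromo would bring the same kind of change on the longer link of compound 2, or at another carbon of the outer ring.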